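Compound 3 to compound 4: sulfonyl to sulfanyl

The source may report more compounds than this note shows. Statements on the series, on what has been measured and on what is new or still open speak of the compounds shown alone.

Measured in a functional assay on DU-145 cells (Homo sapiens) for inhibition, read by trypan blue exclusion, with a stated time of 96 h (on this read-out higher numbers stand for weaker inhibition of growth and lower numbers for stronger inhibition of growth), so far:
- compound 1 `CCOc1ccc(/C=C(\C(=O)c2ccc(Cl)cc2)S(=O)(=O)Cc2ccc(F)cc2)cc1OC` gives 50000 nM
- compound 2 `CCOc1ccc(/C=C(/Sc2ccccc2Cl)C(=O)c2ccc(Cl)cc2)cc1OC` gives 50000 nM
- compound 3 `CCOc1ccc(/C=C(\C(=O)c2ccc(Cl)cc2)S(=O)(=O)Cc2ccccc2Cl)cc1OC` gives 10000 nM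

Compound 3 holds the lowest number of the three. Compound 4 `CCOc1ccc(/C=C(/SCc2ccc(F)cc2)C(=O)c2ccc(Cl)cc2)cc1OC` carries (4-fluorobenzyl)sulfanyl in place of (2-chlorobenzyl)sulfonyl on a double-bonded chain carbon bound to a carbonyl carbon and a double-bonded chain carbon. Two modest measured steps bear on this: one is a 5.0-fold lower number from compound 1 to compound 3 (0.70 log units; beyond the scatter) for the benzyl substituent, the other 5.0-fold lower number from compound 2 to compound 3 (0.70 log units; beyond the scatter) for sulfanyl against sulfonyl. For the measured compounds named here, compound 4 reverts on both counts, so a rise of similar size is expected in this assay, though no measured compound pairs sulfanyl with a benzyl group. The expected move is a 3.0-fold higher number from compound 3 to compound 4 (0.48 log units; beyond the scatter) in this series. For compound 4 the estimate is 30000 nM within a range of 8000 nM to 100000 nM in all.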

Compound 4, concentration for 50% growth inhibition: 1000 nM
Beside the measured number, compound 4's estimate is 30-fold (1.48 log units) above it, and the stated range ends above it.
By their numbers in this assay, from the lowest: compound 4; then compound 3; then compounds 1 and 2 (each within the scatter of the next).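

With the 4-fluorobenzyl group held on the sulfur, sulfanyl in place of sulfonyl gives a 50-fold lower number from compound 1 to compound 4 (1.70 log units; beyond the scatter) in this assay, so the sulfonyl is not favoured at this position when the sulfur carries this benzyl group. With sulfanyl held, 4-fluorobenzyl in place of 2-chlorophenyl gives a 50-fold lower number from compound 2 to compound 4 (1.70 log units; beyond the scatter), and the combined change of substituent and sulfur gives a 10-fold lower number from compound 3 to compound 4 (1.00 log units; beyond the scatter). No supporting data explain these gains.

From the compounds shown here alone, the reading of (2-chlorobenzyl)sulfanyl at this position remains open. So does that of a longer chain on the sulfur, such as phenethyl, or of an amine on the benzyl ring.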